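The source may report more compounds than this note shows. Statements on the series, on what has been measured and on what is new or still open speak of the compounds shown alone.

Working notes on the series. Three compounds share the core of compound 1, `CC(=O)Nc1c(C(O)(C(F)(F)F)C(F)(F)F)ccc2ccccc12`, and differ only in the group on the carbonyl carbon of the amide. In an assay on LtK cells with ATP-sensitive inward rectifier potassium channel 11 (Homo sapiens) as the target (a lower number here means that less compound is needed, a higher number that more compound is needed for the effect), compound 1 gives 18 nM, the lowest of the three numbers. Compound 2, `CC(C)C(=O)Nc1c(C(O)(C(F)(F)F)C(F)(F)F)ccc2ccccc12`, gives 6630 nM, and compound 3, `O=C(Nc1c(C(O)(C(F)(F)F)C(F)(F)F)ccc2ccccc12)c1ccc(Cl)c(Cl)c1`, gives 194 nM. The steps are all large: a 370-fold higher number from compound 1 to compound 2 (2.57 log units; beyond the scatter), an 11-fold higher number from compound 1 to compound 3 (1.03 log units; beyond the scatter) and a 34-fold lower number from compound 2 to compound 3 (1.53 log units; beyond the scatter). Every measured step therefore concerns the group on the carbonyl carbon, and none touches the fused ring system.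

Compound 4, `CC(=O)Nc1c(C(O)(C(F)(F)F)C(F)(F)F)ccc2c(O)cccc12`, keeps the acetamide of compound 1 and changes the ring: hydroxy in place of hydrogen on an aromatic carbon, a hydroxy in place of hydrogen, on an aromatic carbon of a six-membered aromatic ring of carbon only, part of a fused system of two rings, ortho to a fused ring and meta to a fused ring. Among the measured compounds shown here, no measured step bears directly on this change; the measured steps show only that the amide substituent dominates. For the measured compounds named here, with no precedent, the expected effect in this assay is small, not clearly beyond the scatter. For compound 4 the expected step is a 2.2-fold higher number from compound 1 to compound 4 (0.35 log units; beyond the scatter). Compound 4 is estimated at 40 nM, within 8 nM to 250 nM.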

Compound 4, half-maximal effective concentration: 137 nM
Compound 4: the middle estimate sits 3.4-fold (0.53 log units) below what was measured; the range from low to high includes it.
By their numbers in this assay, from the lowest: compound 1; then compounds 4 and 3 (each within the scatter of the next); then compound 2.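

The ring is not a silent part of the series: in this assay, hydroxy in place of hydrogen on an aromatic carbon, ortho to a fused ring and meta to a fused ring, gives a 7.6-fold higher number from compound 1 to compound 4 (0.88 log units; beyond the scatter). Among the compounds shown here, this is the first measured change away from the amide, and at this position the single added hydroxy moves the number in the same direction as every change made to the acetamide of compound 1, though this step is modest and those are large. Nothing on hand accounts for this step.

Open, as far as these compounds go, is whether a methoxy, a fluorine or an amine on the same aromatic carbon would give a similar step. Also open, from the compounds shown here alone, is whether the hydroxy shifts the number to a similar extent when paired with the isopropyl amide of compound 2 or the 3,4-dichlorophenyl amide of compound 3.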